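The source may report more compounds than this note shows. Statements on the series, on what has been measured and on what is new or still open speak of the compounds shown alone.

Measured so far in a functional assay on HepG2 cells (Homo sapiens) for cytotoxicity, read by MTT assay, with a stated time of 48 h; on this read-out lower numbers stand for stronger inhibition and higher numbers for weaker inhibition:
compound 1, `O=C(CSc1nnc(-c2ccncc2)o1)N/N=C/c1ccc(F)cc1`, 12300 nM
compound 2, `O=C(CSc1nnc(-c2ccncc2)o1)N/N=C/c1ccc(Cl)cc1`, 15700 nM
compound 3, `O=C(CSc1nnc(-c2ccncc2)o1)N/N=C/c1ccc([N+](=O)[O-])cc1`, 17900 nM

Compound 2 stands second highest of the three numbers; its gap to compound 3 is a 1.1-fold higher number from compound 2 to compound 3 (0.06 log units; within the scatter), and compound 1 lies at a 1.3-fold higher number from compound 1 to compound 2 (0.11 log units; within the scatter), so all three sit close together. Compound 4, `O=C(CSc1nnc(-c2ccncc2)o1)N/N=C/c1ccccc1O`, differs from compound 2 by 2-hydroxyphenyl in place of 4-chlorophenyl on a carbon with a double bond to nitrogen. The measured steps each exchange one group on the ring that is exchanged here: a 1.3-fold higher number from compound 1 to compound 2 (0.11 log units; within the scatter), a 1.5-fold higher number from compound 1 to compound 3 (0.16 log units; within the scatter) and a 1.1-fold higher number from compound 2 to compound 3 (0.06 log units; within the scatter), none beyond the scatter. Going by the values given here, no measured step introduces a 2-hydroxyphenyl, so the bearing is indirect, and no step beyond the scatter is expected in this assay, in either direction. Compound 4 is estimated at 14000 nM, range 6000 nM to 35000 nM, the expected step being a 1.1-fold lower number from compound 2 to compound 4 (0.05 log units; within the scatter).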

Compound 4, half-maximal inhibitory concentration: 3510 nM
Compound 4: the middle estimate sits 4.0-fold (0.60 log units) above what was measured; measured number outside the range, below it.
By their numbers in this assay, from the lowest: compound 4; then compounds 1, 2 and 3 (each within the scatter of the next).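

In this assay, the group on the carbon with a double bond to nitrogen does affect the number: 2-hydroxyphenyl gives a 4.5-fold lower number from compound 2 to compound 4 (0.65 log units; beyond the scatter), alongside a 3.5-fold lower number from compound 1 to compound 4 (0.54 log units; beyond the scatter) and a 5.1-fold lower number from compound 3 to compound 4 (0.71 log units; beyond the scatter), whereas exchanges among 4-fluorophenyl, 4-chlorophenyl and 4-nitrophenyl stayed within the scatter. This exchange changes the substituent and its place on the ring together, and the compounds shown cannot separate the two. No measured evidence accounts for the step. Open, from the compounds shown here alone, is whether 4-hydroxyphenyl, 2-methoxyphenyl or 2-aminophenyl would keep the lower number. Going by these compounds, whether the step carries over to a change in the shared core also remains open.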